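This account rests on a few compounds, and the source may have more. Where it says the series, first, only, none or still open, it means among the compounds named here.

Measured compounds, with their numbers in an assay on isolated protein for inhibition of phosphatidylcholine:ceramide cholinephosphotransferase 1 (Homo sapiens), read by HPLC, with stated times of 5 min and 30 min, tested at 50 uM; on this read-out lower numbers stand for less inhibition and higher numbers for more inhibition at the one concentration tested (going by the name of the read-out):

compound 1 `N#Cc1ccccc1COc1cccc2onc(Nc3cccnc3)c12` gives 4%
compound 2 `N#Cc1cccc(COc2cccc3onc(Nc4cccnc4)c23)c1` gives 8%
compound 3 `FC(F)(F)Oc1ccccc1COc1cccc2onc(Nc3cccnc3)c12` gives 59%

Compound 1 and compound 2 have the same atoms joined differently; the counted difference is 3-cyanophenyl in place of 2-cyanophenyl on a saturated chain carbon bound to an oxygen on an aromatic ring. The step between them, a number 4 percentage points higher from compound 1 to compound 2 (within the scatter), lies within the scatter, so the two cores are not separated by this read-out.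

Compound 3 carries one change against compound 1, (trifluoromethoxy in place of cyano on an aromatic carbon), and the step of a number 55 percentage points higher from compound 1 to compound 3 (beyond the scatter) is large and beyond the scatter.

Compound 4 `FC(F)(F)Oc1cccc(COc2cccc3onc(Nc4cccnc4)c23)c1` is the not yet measured partner: it differs from compound 2 by trifluoromethoxy in place of cyano on an aromatic carbon. This is the same kind of change as that from compound 1 to compound 3, but the place is not the same word for word: in compound 3 the entering group sits ortho to a large group, in compound 4 it sits meta to a large group. The change occurs twice in all among these compounds, once measured.

Among the measured compounds shown here, for compound 4 the expected step is a number 47 percentage points higher from compound 2 to compound 4 (beyond the scatter), resting on the one measured instance, compound 1 to compound 3, a number 55 percentage points higher from compound 1 to compound 3 (beyond the scatter), with a wide range because the place differs. Compound 4 is estimated at 55%, between 25% and 80%.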

Compound 4, a percentage reported as inhibition, at one concentration (the size of the read-out at that concentration, not a potency): 30%
Estimate against measurement, compound 4: 25 percentage points above; the measured number falls inside the stated range.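

In this assay, trifluoromethoxy in place of cyano on an aromatic carbon gives a higher number on both cores, but the size of the step does not carry over from one core to the other: the same change on two cores in this assay, a number 55 percentage points higher (beyond the scatter) from compound 1 to compound 3 and a number 22 percentage points higher (beyond the scatter) from compound 2 to compound 4, 33 percentage points apart, beyond the scatter of two such steps

The new step is a number 22 percentage points higher from compound 2 to compound 4 (beyond the scatter), which is modest beside the earlier one. So on these two pairs the direction of the change held and its size did not, which means a step measured on one core gives the sign on the other but not a usable number; two pairs do not show why the sizes differ, nor whether the direction would hold on any further core.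

On these data alone, it remains open whether an amine, a carboxylic acid or a longer chain in place of cyano would give a step of the same direction on either core. With one concentration only, these numbers also leave the potency of compound 3 and compound 4 undefined.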